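Trimming a propyl chain to ethyl

A few compounds are considered here, and "the series" means these few. Any claim that something is new, unique, unknown or untested is made for them only; others in the source may bear on it.

Results so far in an ADME assay on a cell-free system (plasma, Mus musculus) for protein binding, using equilibrium dialysis, with a stated time of 5 h, tested at 10 uM (a higher number here means a larger unbound share of the compound, a lower number a smaller unbound share), stand as follows
compound 1 `CC[C@@H](c1ccc(C(=O)O)c(Oc2cccc(Cl)c2)c1F)N1CCC[C@H](n2cc(C)c(=O)[nH]c2=O)C1` with the entry "not determined" (no result reported) and no number
compound 2 `CC[C@H](c1ccc(C(=O)O)c(Oc2cccc(Cl)c2)c1OC)N1CCC[C@H](n2cc(C)c(=O)[nH]c2=O)C1` with the value 0.006 as its unbound fraction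
compound 3 `CCC[C@@H](c1ccc(C(=O)O)c(Oc2cccc(Cl)c2)c1OC)N1CCC[C@H](n2cc(C)c(=O)[nH]c2=O)C1` with the entry "not determined" (no result reported) and no number

Compound 3 has no single number in this assay, and compound 1 is the one further entry in that position. The only figure available is therefore that of compound 2 at 0.006 as its unbound fraction, a small unbound share.

Compound 4 `CC[C@@H](c1ccc(C(=O)O)c(Oc2cccc(Cl)c2)c1OC)N1CCC[C@H](n2cc(C)c(=O)[nH]c2=O)C1` has not yet been measured. It arises from compound 3 through hydrogen in place of methyl on a saturated chain carbon, three bonds along the chain from an amine nitrogen in a ring and an aromatic carbon on a saturated chain carbon, three bonds along the chain from an amine nitrogen in a ring and an aromatic carbon, so that propyl becomes ethyl. Among the compounds with values here, no measured step in this set shows what such a change does, and compound 3 offers no number to start from. In this assay no step beyond the scatter is expected, in either direction, and the expectation leans on compound 2 with its 0.006 as the sole anchor.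

Compound 4 is expected at an estimated unbound fraction of 0.006 within a range of 0.002 to 0.018 as the likely span of the coming measurement.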

Compound 4, unbound fraction: 0.011
Compound 4: middle estimate off by 1.8-fold (0.26 log units), on the low side; the measured number falls inside the stated range.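

Within the data shown here, with compound 4, a second number stands in this assay, and it gives the first readable step in this set, a 1.8-fold higher number from compound 2 to compound 4 (0.26 log units; within the scatter). That step concerns only the stereocentre at the saturated chain carbon carrying the ethyl group, drawn R in compound 2 and S in compound 4: the fact that compounds 2 and 4 differ only in the configuration as drawn. For this pair, the two configurations at that centre cannot be told apart in this assay, and an ethyl chain gives a number in each of them.

Steps involving compound 1 or compound 3 cannot be read, and what the change from propyl to ethyl does at this position in this assay stays open, as does any comparison of the fluoro compound 1 with its methoxy counterpart. Also open, as far as these compounds go, is how a butyl chain or a chain bearing a hydroxyl group at this saturated chain carbon would read, and whether the two configurations would still lie within the scatter of each other with such groups in place.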